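Cytotoxicity of a tolerated analogue when a ring substituent changes

The source may report more compounds than this note shows. Statements on the series, on what has been measured and on what is new or still open speak of the compounds shown alone.

Measured compounds:
- compound 1, `CC1=C(C(=O)Nc2ccc(Cl)cc2)C(c2ccccc2)C(C(=O)Nc2ccc(Cl)cc2)=C(C)N1`: 15 ug/mL
- compound 2, `COc1cc(C2C(C(=O)Nc3ccc(Cl)cc3)=C(C)NC(C)=C2C(=O)Nc2ccc(Cl)cc2)ccc1O`: 250 ug/mL

In an ADME assay on Vero cells (Chlorocebus sabaeus) for cytotoxicity, read by sulforhodamine B assay, with a stated time of 3 days (a higher number here means that more compound is tolerated, a lower number that less compound is tolerated), compound 2 gives the highest of the two numbers shown, and compound 1 gives a much lower number, so compound 2 is the better tolerated of the pair. Among the compounds with values here, the only measured step is a 17-fold higher number from compound 1 to compound 2 (1.22 log units; beyond the scatter), a large one, obtained with 4-hydroxy-3-methoxyphenyl in place of phenyl on a saturated ring carbon.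

Compound 3, `CC1=C(C(=O)Nc2ccc(Cl)cc2)C(c2ccccc2O)C(C(=O)Nc2ccc(Cl)cc2)=C(C)N1`, has not yet been tested. It differs from compound 2 in one place: 2-hydroxyphenyl in place of 4-hydroxy-3-methoxyphenyl on a saturated ring carbon.

Within the data shown here, no measured step covers this exact change. The one step shown, a 17-fold higher number from compound 1 to compound 2 (1.22 log units; beyond the scatter), suggests that the group on this saturated ring carbon can move the number a lot, and 2-hydroxyphenyl sits somewhere in character between the two measured groups. Compound 3 is therefore expected to lose part of the gain, with a 3.1-fold lower number from compound 2 to compound 3 (0.49 log units; beyond the scatter) as the estimated step. The estimated value for compound 3 is 80 ug/mL, within a range of 25 ug/mL to 250 ug/mL.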

Compound 3, half-maximal cytotoxic concentration: 62 ug/mL
The estimate for compound 3 lay 1.3-fold (0.11 log units) above the measured number; the measured number falls inside the stated range.
By their numbers in this assay, from the lowest: compound 1; then compound 3; then compound 2.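

In this assay, adding a single hydroxy to the phenyl group on the saturated ring carbon gives a 4.1-fold higher number from compound 1 to compound 3 (0.62 log units; beyond the scatter), so even this small change at the position moves the number beyond the scatter. Both hydroxy-bearing groups beat plain phenyl, but they are not equal: 2-hydroxyphenyl in place of 4-hydroxy-3-methoxyphenyl gives a 4.0-fold lower number from compound 2 to compound 3 (0.61 log units; beyond the scatter), so having a hydroxy on the ring does not by itself reach the highest number seen here. Nothing available explains why these groups differ in this way.

Compound 3 differs from compound 2 in both the hydroxy's place and the loss of the methoxy, so the share of each change cannot be separated. On these data alone, how an amine or a carboxylic acid on this phenyl ring would behave also remains open.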